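This account rests on a few compounds, and the source may have more. Where it says the series, first, only, none or still open, it means among the compounds named here.

Going by the values given here, in a functional assay on NCI-H460 cells (Homo sapiens) for antiproliferative activity, read by MTT assay, with a stated time of 48 h (a higher number here means a weaker inhibitor, a lower number a stronger inhibitor), only two compounds have numbers so far. Compound 1 `Cc1ccc(Nc2ccc3c(c2)/C(=C\C2CCCCC2)C(=O)N3)cc1` gives 45500 nM. Compound 2 `CCCCC1(O)C(=O)Nc2ccc(Nc3ccc(C)cc3)cc21` gives 31800 nM. These two values lie within the usual scatter of repeated measurements, so compound 2 cannot be ranked apart from compound 1. Compound 3 `Cc1ccc(Nc2ccc3c(c2)C(O)(CCC(C)C)C(=O)N3)cc1` differs from compound 2 in a single place: methyl in place of hydrogen on a saturated chain carbon bound to two saturated chain carbons. This is a methyl in place of hydrogen on a saturated chain carbon bound to two saturated chain carbons, which turns butyl into isopentyl. Among the compounds with values here, no measured pair shows what such a change does in this assay, so the expectation is for no shift beyond the scatter, in either direction. The expected step of a 1.1-fold lower number from compound 2 to compound 3 (0.03 log units; within the scatter) is therefore small. Compound 3 is estimated at 30000 nM, with an expected range from 14000 nM to 60000 nM.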

Compound 3, half-maximal inhibitory concentration: 22700 nM
The estimate for compound 3 lay 1.3-fold (0.12 log units) above the measured number; the measured number falls inside the stated range.
By their numbers in this assay, from the lowest: compounds 3, 2 and 1 (each within the scatter of the next).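

In this assay, going by these compounds alone, the methyl in place of hydrogen on a saturated chain carbon bound to two saturated chain carbons gives a 1.4-fold lower number from compound 2 to compound 3 (0.15 log units; within the scatter) and so provides the first measured comparison of two compounds that differ in one place. At this position, butyl and isopentyl cannot be told apart, so this one added methyl has no effect that can be separated from ordinary measurement scatter. No measurement available here offers an explanation for this result.

On these data alone, whether an amine, a carboxylic acid or a longer chain at this place would move the number beyond the scatter remains open. This single pair also says nothing about how the same methyl would behave elsewhere on the shared core.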